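Trimming an aryl group to methyl on the imidazole-type core

The source may hold more compounds than are shown below. What is called first, only, known or untested is meant among the compounds shown, and "the series" means these compounds.

Compound 1 `Fc1cc(-c2nc(N3CCN(c4ncccc4C(F)(F)F)CC3)[nH]c2-c2ccc(C(F)(F)F)cc2)cc(F)c1F` gives 20 nM in a functional assay on CHO cells for antagonist activity at transient receptor potential cation channel subfamily V member 1 (Rattus norvegicus), read by calcium flux, at pH 5 (a higher number here means a weaker inhibitor, a lower number a stronger inhibitor), the lowest number among the three measured compounds. Its nearest neighbour is compound 2 `Fc1cc(-c2nc(N3CCN(c4ncccc4C(F)(F)F)CC3)[nH]c2-c2cc(F)c(F)c(F)c2)cc(F)c1F` with 32 nM, and the step of a 1.6-fold higher number from compound 1 to compound 2 (0.20 log units; within the scatter) swaps one aromatic ring for another. Compound 3 `C[C@@H]1CN(c2ncccc2C(F)(F)F)CCN1c1nc(-c2ccccc2)c(-c2ccc(C(F)(F)F)cc2)[nH]1`, which differs in two places, gives 341 nM. Compound 4 `Cc1nc(N2CCN(c3ncccc3C(F)(F)F)CC2)[nH]c1-c1ccc(C(F)(F)F)cc1` arises from compound 1 through the change (methyl in place of 3,4,5-trifluorophenyl on an aromatic carbon). Among the measured compounds shown here, no measured step removes a whole aromatic ring at this position; the only step that touches this position, from compound 1 to compound 2, exchanges two rings and stays within the scatter. A much smaller group there is expected to cost potency, so compound 4 is expected to give 250 nM, between 60 nM and 1500 nM, a step of a 13-fold higher number from compound 1 to compound 4 (1.10 log units; beyond the scatter).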

Compound 4, half-maximal inhibitory concentration: > 4000 nM
Compound 4: a limit, no number; the forecaster's own chance of this, stated with the estimate: 10%; middle value at least 16-fold (1.20 log units) away from the limit.
By their numbers in this assay, from the lowest: compounds 1 and 2 (each within the scatter of the next); then compound 3. At a limit, above all of these: compound 4.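

Putting methyl in place of 3,4,5-trifluorophenyl on this aromatic carbon gives an at least 200-fold higher number from compound 1 to compound 4 (2.30 log units; beyond the scatter). The earlier step, a 1.6-fold higher number from compound 1 to compound 2 (0.20 log units; within the scatter), exchanged one aromatic ring for another, whereas this one shows that in this assay losing the ring altogether for methyl is a large change. The result for compound 4 is a limit, not a number: the limit of > 4000 nM in this assay, at which 1 of the 4 values shown sits.

The compounds shown leave open whether an aromatic ring is needed at this carbon or whether another group could take its place. A cyclohexyl ring or a butyl chain there could help separate those two possibilities.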